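Swapping Chloro for Difluoromethyl on the Pyridine Ring

This account rests on a few compounds, and the source may have more. Where it says the series, first, only, none or still open, it means among the compounds named here.

Compound 3 `CC(C)c1ccc(NC(=O)N2CCN(c3ncccc3Cl)CC2)cc1` has the lowest number of the three measured compounds in a functional assay on HEK293 cells for antagonist activity at transient receptor potential cation channel subfamily V member 1 (Rattus norvegicus) (a lower number here means a stronger inhibitor, a higher number a weaker inhibitor), giving 17.3 nM. Compound 1 `CC(C)(C)c1ccc(NC(=O)N2CCN(c3ncccc3C(F)(F)F)CC2)cc1` gives 57.7 nM, and compound 2 `CC(C)(C)c1ccc(NC(=S)N2CCN(c3ncccc3C(F)(F)F)CC2)cc1` gives 441 nM; both lie beyond the scatter from compound 3. Compound 4 `CC(C)c1ccc(NC(=O)N2CCN(c3ncccc3C(F)F)CC2)cc1` differs from compound 3 in a single place: difluoromethyl in place of chloro on an aromatic carbon. For the measured compounds named here, no measured pair shows this same change, so its effect in this assay cannot be read from the data. The step is expected to be modest, in the direction of a somewhat higher number, and may not reach beyond the scatter: a 1.6-fold higher number from compound 3 to compound 4 (0.21 log units; within the scatter). Compound 4 is accordingly estimated at 28 nM, with a range from 9 nM to 90 nM.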

Compound 4, half-maximal inhibitory concentration: 61.5 nM
Estimate against measurement, compound 4: 2.2-fold (0.34 log units) below, within the range that was stated.
By their numbers in this assay, from the lowest: compound 3; then compounds 1 and 4 (each within the scatter of the next); then compound 2.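

In this assay, for the compounds shown here, replacing 3-chloropyridin-2-yl with 3-(difluoromethyl)pyridin-2-yl gives a 3.6-fold higher number from compound 3 to compound 4 (0.55 log units; beyond the scatter) and provides the first direct comparison at this position. Here, chloro is the better of the two groups, although compound 4 remains an inhibitor with the larger difluoromethyl group in place. Nothing shown explains the step.

As far as these compounds go, it remains open whether bromo, methyl or nitrile at this position would give a number closer to that of compound 3 or compound 4. From the compounds shown here alone, it also remains open whether the step would be the same on a different core.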